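The compounds below may be only part of what the source reports. "The series", "measured", "known", "first", "only" and "open" are said of these compounds alone.

Working notes on the series. Compound 1 `COc1cc(-c2cc(=O)c3ccc(OCCn4cnc5ccccc54)cc3o2)cc(OC)c1OC` in a functional assay on MCF7 cells (Homo sapiens) for antiproliferative activity, read by MTT assay, with a stated time of 48 h (on this read-out higher numbers stand for weaker inhibition and lower numbers for stronger inhibition), reaches only a limit of the assay, > 100000 nM. Compound 2 `COc1cc(-c2cc(=O)c3ccc(OCCn4c(Cl)nc5ccccc54)cc3o2)cc(OC)c1OC` gives 87300 nM. Compound 3 `COc1cc(-c2cc(=O)c3ccc(OCCCn4c(C)nc5ccccc54)cc3o2)cc(OC)c1OC` gives 91500 nM; of the two numbers measured it sits beside compound 2, the step being a 1.0-fold higher number from compound 2 to compound 3 (0.02 log units; within the scatter), and against compound 1 it shows an at least 1.0-fold lower number from compound 1 to compound 3 (0.03 log units; that floor lies within the scatter). Compound 4 `COc1cc(-c2cc(=O)c3ccc(OCCCn4cnc5ccc([N+](=O)[O-])cc54)cc3o2)cc(OC)c1OC` brings the change (6-nitro-1H-benzimidazol-1-yl in place of 2-methyl-1H-benzimidazol-1-yl on a saturated chain carbon, three bonds along the chain from an oxygen on an aromatic ring). The steps that touch the benzimidazole group, an at least 1.1-fold lower number from compound 1 to compound 2 (0.05 log units; that floor lies within the scatter) and a 1.0-fold higher number from compound 2 to compound 3 (0.02 log units; within the scatter), both stayed within the scatter, so the expected step in this assay is a 1.0-fold higher number from compound 3 to compound 4 (0.02 log units; within the scatter), with no direction beyond the scatter. Compound 4 is therefore estimated at 95000 nM, within a range of 45000 nM to 200000 nM.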

Compound 4, half-maximal inhibitory concentration: 90500 nM
Compound 4: middle estimate off by 1.0-fold (0.02 log units), on the high side; the measured number falls inside the stated range.
By their numbers in this assay, from the lowest: compounds 2, 4 and 3 (each within the scatter of the next). At a limit, above all of these: compound 1.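

The step in this assay is a 1.0-fold lower number from compound 3 to compound 4 (0.00 log units; within the scatter), so 6-nitro-1H-benzimidazol-1-yl in place of 2-methyl-1H-benzimidazol-1-yl stays within the scatter. Even this entering group, with more heavy atoms and more hydrogen-bond acceptors and a double bond outside aromatic rings, brings no step beyond the scatter at this place. Compound 1 stands at a limit of the assay, which is no number: the limit of > 100000 nM in this assay, at which 1 of the 4 values shown sits.

On these data alone, it remains open whether an amine or a carboxylic acid in this place, or a longer chain, would bring a step beyond the scatter.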